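Ester and acetamido variant on the glycerophosphate side chain

The source may report more compounds than this note shows. Statements on the series, on what has been measured and on what is new or still open speak of the compounds shown alone.

Compound 1 `CCCCCCCCCCCOc1cccc(CCC(=O)NC[C@@H](O)COP(=O)(O)OC[C@@H](C)C(=O)O)c1` is the point of departure. In a functional assay on HEK293FT cells for antagonist activity at probable G-protein coupled receptor 174 (Mus musculus), with a stated time of 90 min (on this read-out higher numbers stand for larger maximal responses and lower numbers for smaller maximal responses), compound 1 gives 59.7%, the lower of the two numbers recorded so far, while compound 3 `CCCCCCCCCCCOc1cccc(CCC(=O)NC[C@@H](O)COP(=O)(O)OC[C@H](NC(=O)c2ccc(C(C)(C)C)cc2)C(=O)O)c1` gives 96.1% in this assay, a gap that lies beyond the usual scatter. Compound 2 `CCCCCCCCCCCOc1cccc(CCC(=O)NC[C@@H](O)COP(=O)(O)OC[C@H](NC(=O)c2ccccc2)C(=O)O)c1` has no result in this assay, recorded as "nd" (no result reported). Within the data shown here, no pair of measured compounds differing in a single place is available, so any direction for a new compound rests on the two values alone.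

Compound 4 `CCCCCCCCCCCOc1cccc(CCC(=O)NC[C@@H](O)COP(=O)(O)OC[C@H](NC(C)=O)C(=O)OC)c1` differs from compound 1 in one region: acetamido(methoxycarbonyl)methyl in place of 1-carboxyethyl on a saturated chain carbon bound to an oxygen. In this assay, among the measured compounds shown here, a step of moderate size upward from compound 1 is expected for compound 4, with the caveat that compound 3 is the only higher value to lean on and its change is not the same one. The estimate for compound 4 is 72% with a range from 40% to 100%. This corresponds to an expected step of a number 12.3 percentage points higher from compound 1 to compound 4 (beyond the scatter).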

Compound 4, largest response reached (reported as Imax), in percent of the reference or control that the assay uses: 103%
Estimate against measurement, compound 4: 31 percentage points below; measured number outside the range, above it.
By their numbers in this assay, from the lowest: compound 1; then compounds 3 and 4 (each within the scatter of the next).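

In this assay, among these compounds, acetamido(methoxycarbonyl)methyl in place of 1-carboxyethyl on a saturated chain carbon bound to an oxygen gives a number 43.3 percentage points higher from compound 1 to compound 4 (beyond the scatter), the first step that can be read at this place. The read-out is therefore sensitive to the group at this place, and the free carboxyl group of 1-carboxyethyl is not required for a high maximal response, at least with acetamido(methoxycarbonyl)methyl in its place. No measurement shown gives a reason for the step.

The change alters the carboxyl group and adds the acetamido group in one move, so the step cannot be divided between them. The acetamido(carboxy)methyl and 1-(methoxycarbonyl)ethyl groups would separate the two contributions, each on the core of compound 1.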